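A few compounds are considered here, and "the series" means these few. Any claim that something is new, unique, unknown or untested is made for them only; others in the source may bear on it.

Going by the values given here, in a functional assay on A549 cells (Homo sapiens) for antiproliferative activity, read by MTT assay (on this read-out lower numbers stand for stronger inhibition and higher numbers for weaker inhibition), three compounds built on a shared core have numbers so far: compound 1 `COc1cc2c(Oc3ccc(NC(=O)Nc4ccccc4Cl)cc3)ccnc2cc1OCCCCCCC(=O)NO` gives 1910 nM, compound 2 `COc1cc2c(Oc3ccc(NC(=O)Nc4ccccc4C(F)(F)F)cc3)ccnc2cc1OCCCCCCC(=O)NO` gives 5280 nM, and compound 3 `COc1cc2c(Oc3ccc(NC(=O)NC4CCCCC4)cc3)ccnc2cc1OCCCCCCC(=O)NO` gives 850 nM. Compound 3 therefore has the lowest number of the three, and its steps to both others lie beyond the scatter. Compound 4 `COc1cc2c(Oc3ccc(NC(=O)N/N=C/c4ccccc4)cc3)ccnc2cc1OCCCCCCC(=O)NO` differs from compound 3 by one change: a group of 8 heavy atoms (7 carbon, 1 nitrogen; one six-membered aromatic ring of carbon only) in place of a group of 6 heavy atoms (6 carbon; one six-membered non-aromatic ring of carbon only), on an amide-type nitrogen. The entering group, like those in compound 1 and compound 2, has a six-membered aromatic ring of carbon only, so the closest evidence is the pair of steps that swap such a group for cyclohexyl: a 2.2-fold lower number from compound 1 to compound 3 (0.35 log units; beyond the scatter) and a 6.2-fold lower number from compound 2 to compound 3 (0.79 log units; beyond the scatter). The ring substituent also matters, as shown by a 2.8-fold higher number from compound 1 to compound 2 (0.44 log units; beyond the scatter). Among the compounds with values here, no measured compound has the nitrogen or the double bond of the entering group, so this guidance is loose. A modest rise is expected in this assay, and the expected step is a 1.8-fold higher number from compound 3 to compound 4 (0.25 log units; within the scatter). For compound 4 the estimated value is 1500 nM, with an expected range from 500 nM to 5000 nM.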

Compound 4, half-maximal inhibitory concentration: 3700 nM
For compound 4 the middle estimate is 2.5-fold (0.39 log units) below the measured one, within the range that was stated.
By their numbers in this assay, from the lowest: compound 3; then compounds 1, 4 and 2 (each within the scatter of the next, the first and the last beyond it).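

In this assay, replacing cyclohexyl on this amide-type nitrogen with a group carrying a nitrogen and a double bond outside the aromatic ring costs activity (a 4.4-fold higher number from compound 3 to compound 4 (0.64 log units; beyond the scatter)), so a second type of aromatic group joins the earlier two in standing apart from cyclohexyl. Its distance from the two groups with a substituted aromatic ring lies within the scatter (a 1.4-fold lower number from compound 2 to compound 4 (0.15 log units; within the scatter); a 1.9-fold higher number from compound 1 to compound 4 (0.29 log units; within the scatter)), even though compound 1 and compound 2 are separated from each other beyond it. Nothing measured here bears on the reason for this result.

Going by these compounds, whether the nitrogen or the double bond of the entering group carries the step stays open. So does whether an unsubstituted phenyl or a benzyl group on this nitrogen would track cyclohexyl or the aromatic groups.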